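Swapping an Amino for a Bromo on a Benzyl Ring

The source may report more compounds than this note shows. Statements on the series, on what has been measured and on what is new or still open speak of the compounds shown alone.

Compound 3 `COc1ccc(CN(C(=O)CSc2nc3ccccc3s2)c2cc(OC)c(OC)c(OC)c2)cc1N` belongs to a set of three compounds tested in a functional assay on PC-3 cells (Homo sapiens) for antiproliferative activity, read by MTT assay, with a stated time of 48 h (a higher number here means a weaker inhibitor, a lower number a stronger inhibitor), where compound 3 gives 7510 nM. Compound 1 `COc1ccc2nc(SCC(=O)N(Cc3ccc(OC)c(O)c3)c3cc(OC)c(OC)c(OC)c3)sc2c1` gives 4110 nM and compound 2 `COc1ccc(CN(C(=O)CSc2nc3cc(Br)ccc3s2)c2cc(OC)c(OC)c(OC)c2)cc1O` gives 8210 nM; compound 3 stands second highest of the three numbers, yet all three lie within the scatter of one another. Among the measured compounds shown here, the one step between measured neighbours, a 2.0-fold higher number from compound 1 to compound 2 (0.30 log units; within the scatter), changes the group on a sulfur and says nothing about the benzyl part. Compound 4 `COc1ccc(CN(C(=O)CSc2nc3ccccc3s2)c2cc(OC)c(OC)c(OC)c2)cc1Br` differs from compound 3 only in that part: bromo in place of amino on an aromatic carbon. For the measured compounds named here, no measured step bears on this change, so nothing beyond the scatter is expected. Compound 4 is expected to give 7500 nM, between 3000 nM and 19000 nM. The expected step is a 1.0-fold lower number from compound 3 to compound 4 (0.00 log units; within the scatter).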

Compound 4, half-maximal inhibitory concentration: 16000 nM
Compound 4: the middle estimate sits 2.1-fold (0.33 log units) below what was measured; low and high end bracket the measured number.
By their numbers in this assay, from the lowest: compounds 1, 3, 2 and 4 (each within the scatter of the next, the first and the last beyond it).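

In this assay, the step of a 2.1-fold higher number from compound 3 to compound 4 (0.33 log units; beyond the scatter) is modest, but it shows that the group at this position, ortho to a methoxy group, can shift the number when amino gives way to bromo. It is the only step shown that touches the benzyl part, and the only one beyond the scatter. Nothing measured here accounts for the step.

From the compounds shown here alone, whether chloro or methyl at this position would give a number closer to compound 3 or to compound 4 remains open. Also open, going by these compounds, is whether bromo in place of amino gives a similar step on the core of compound 1.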